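A few compounds are considered here, and "the series" means these few. Any claim that something is new, unique, unknown or untested is made for them only; others in the source may bear on it.

In a physicochemical assay for solubility, at pH 7.4 (a lower number here means a less soluble compound, a higher number a more soluble compound), compound 1 (`Cc1ccc(NC(=O)Nc2cc(C)nc3ccccc23)cc1`) gives 1300 nM and compound 2 (`Cc1cc(NC(=O)Nc2ccc(O)cc2)c2ccccc2n1`) gives 100 nM as the lower of the two numbers. For the measured compounds named here, the one measured step (a 13-fold lower number from compound 1 to compound 2 (1.11 log units; beyond the scatter)) is large and beyond the scatter, with hydroxy in place of methyl on an aromatic carbon. Compound 3 (`Cc1cc(NC(=O)Nc2ncccc2C)c2ccccc2n1`) differs from compound 2 by a single exchange (3-methylpyridin-2-yl in place of 4-hydroxyphenyl on an amide-type nitrogen): 3-methylpyridin-2-yl in place of 4-hydroxyphenyl on an amide-type nitrogen. Going by the values given here, the hydroxy leaves and a methyl comes back, but as part of a group that no measured compound carries. Compound 1 has no hydroxy and gives 1300 nM so a large rise in this assay is expected, close to the reverse of the measured step (a 13-fold lower number from compound 1 to compound 2 (1.11 log units; beyond the scatter)). A single step is thin evidence for a new group, so this expectation stays loose and the range has to be wide. The expected step is an upward one (an 8.0-fold higher number from compound 2 to compound 3 (0.90 log units; beyond the scatter)), somewhat smaller than the measured step. Compound 3 is thus estimated at 800 nM (150 nM to 4000 nM).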

Compound 3, solubility: 1300 nM
For compound 3 the middle estimate is 1.6-fold (0.21 log units) below the measured one; measured number inside the range.
By their numbers in this assay, from the lowest: compound 2; then compounds 1 and 3 (each within the scatter of the next).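

In this assay, the step of a 13-fold higher number from compound 2 to compound 3 (1.11 log units; beyond the scatter) shows that at this place on the amide-type nitrogen, 3-methylpyridin-2-yl does not share the low number of 4-hydroxyphenyl. The step of no change at the digits printed from compound 1 to compound 3 (within the scatter) adds what compound 1 and compound 2 alone could not show: 3-methylpyridin-2-yl and 4-methylphenyl cannot be told apart here, so among these three compounds only compound 2, the one carrying 4-hydroxyphenyl, stands apart. No other measurement bears on these numbers, so the link between group and number remains a plain observation across three compounds.

The compounds shown leave open whether the low number of compound 2 belongs to the hydroxy group in particular or would also appear with another group carrying a hydrogen-bond donor, such as an amine, on the same ring. Also open, as far as these compounds go, is what the ring nitrogen and the methyl of 3-methylpyridin-2-yl each contribute, which an unsubstituted pyridin-2-yl group could help to separate.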